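Amide aryl variation on a shared flavonol core

The compounds below may be only part of what the source reports. "The series", "measured", "known", "first", "only" and "open" are said of these compounds alone.

Compound 1 `COc1ccccc1C(=O)Nc1cccc(-c2oc3cc(-c4ccc(F)cc4)ccc3c(=O)c2O)c1` gives 9050 nM. Compound 2 `COc1cccc(C(=O)Nc2cccc(-c3oc4cc(-c5ccc(F)cc5)ccc4c(=O)c3O)c2)c1` gives 18900 nM. Compound 3 `O=C(Nc1cccc(-c2oc3cc(-c4ccc(F)cc4)ccc3c(=O)c2O)c1)c1cccc(F)c1` gives 6590 nM.

All three were measured in a functional assay on HCC1937 cells (Homo sapiens) for antiproliferative activity, read by CCK-8 assay, with a stated time of 72 h; on this read-out lower numbers stand for stronger inhibition and higher numbers for weaker inhibition. Compound 3 stands with the lowest of the three numbers: compound 1 is close to it, the step of a 1.4-fold lower number from compound 1 to compound 3 (0.14 log units; within the scatter) lying within the scatter, while compound 2 is further away, as the step of a 2.9-fold lower number from compound 2 to compound 3 (0.46 log units; beyond the scatter) shows. Between compound 1 and compound 2 the step of a 2.1-fold higher number from compound 1 to compound 2 (0.32 log units; beyond the scatter) is modest.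

Compound 4 `Cc1cc(C(=O)Nc2cccc(-c3oc4cc(-c5ccc(F)cc5)ccc4c(=O)c3O)c2)ccc1F` differs from compound 3 in one place: 4-fluoro-3-methylphenyl in place of 3-fluorophenyl on a carbonyl carbon. Within the data shown here, no measured step tests a methyl on this phenyl, and the steps that bear on it only concern the identity and position of a single substituent, namely a 2.9-fold lower number from compound 2 to compound 3 (0.46 log units; beyond the scatter) and a 2.1-fold higher number from compound 1 to compound 2 (0.32 log units; beyond the scatter), both modest. He therefore expects compound 4 to show a step of a 1.1-fold lower number from compound 3 to compound 4 (0.04 log units; within the scatter), no larger than the scatter, in either direction. Compound 4 is estimated at 6000 nM, with a range from 2500 nM to 14000 nM.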

Compound 4, half-maximal inhibitory concentration: 5420 nM
Beside the measured number, compound 4's estimate is 1.1-fold (0.04 log units) above it, within the range that was stated.
By their numbers in this assay, from the lowest: compounds 4, 3 and 1 (each within the scatter of the next); then compound 2.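

In this assay, a phenyl on the carbonyl carbon that carries both a fluoro and a methyl, as 4-fluoro-3-methylphenyl, cannot be told apart from 3-fluorophenyl, with a 1.2-fold lower number from compound 3 to compound 4 (0.08 log units; within the scatter). It also cannot be told apart from 2-methoxyphenyl, with a 1.7-fold lower number from compound 1 to compound 4 (0.22 log units; within the scatter), so compound 1, compound 3 and compound 4 sit together, while compound 2, with its 3-methoxyphenyl, stands apart by a modest margin, with a 3.5-fold lower number from compound 2 to compound 4 (0.54 log units; beyond the scatter). No evidence at hand accounts for this separation of compound 2.

The compounds shown leave open whether a larger change at this position would move the number beyond the scatter, such as a phenyl carrying an amine or a carboxylic acid. They also leave open how a 3-methylphenyl, with the methyl alone, would compare with compound 3.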